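Aryl variation on the shared core: outlook for compound 4

The source may report more compounds than this note shows. Statements on the series, on what has been measured and on what is new or still open speak of the compounds shown alone.

Compound 3 `c1ccc2c(-c3cn4ccnc4c(-c4ccc5ncn(C6CCCCC6)c5c4)n3)cccc2c1` stands second highest of the three numbers in a functional assay on SNB-19 cells (Homo sapiens) for inhibition, read by sulforhodamine B assay, with a stated time of 48 h, tested at 10 uM (on this read-out lower numbers stand for less inhibition and higher numbers for more inhibition at the one concentration tested (going by the name of the read-out)), where compound 3 gives 9.08%. Compound 1 `Brc1cn2ccnc2c(-c2ccc3ncn(C4CCCCC4)c3c2)n1` gives 8.09%, and a number 1 percentage points higher from compound 1 to compound 3 (within the scatter). Compound 2 `c1ccc(-c2cn3ccnc3c(-c3ccc4ncn(C5CCCCC5)c4c3)n2)cc1` gives 22.9%, and a number 13.8 percentage points lower from compound 2 to compound 3 (beyond the scatter). Compound 4 `Fc1ccc(-c2cn3ccnc3c(-c3ccc4ncn(C5CCCCC5)c4c3)n2)cc1` differs from compound 3 by 4-fluorophenyl in place of naphthalen-1-yl on an aromatic carbon. Compound 4 again carries a single six-membered ring, so a number 13.8 percentage points lower from compound 2 to compound 3 (beyond the scatter) bears most directly on it, and a number 14.8 percentage points higher from compound 1 to compound 2 (beyond the scatter) points the same way, with phenyl lifting the read-out over bromo. For the measured compounds named here, no measured step shows what fluorine on the phenyl adds. Compound 4 is therefore expected to recover roughly what the larger ring cost, an estimated step of a number 11.9 percentage points higher from compound 3 to compound 4 (beyond the scatter). The estimate for compound 4 is 21%, between 8% and 36%.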

Compound 4, a percentage reported as inhibition, at one concentration (the size of the read-out at that concentration, not a potency): 14.2%
Estimate against measurement, compound 4: 6.8 percentage points above, and the stated range covers the measured number.
By their numbers in this assay, from the lowest: compounds 1, 3, 4 and 2 (each within the scatter of the next, the first and the last beyond it).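

In this assay fluoro in place of hydrogen on the phenyl gives a number 8.7 percentage points lower from compound 2 to compound 4 (within the scatter) and so adds nothing that can be told from the scatter. With 4-fluorophenyl on this aromatic carbon, neither a number 5.1 percentage points higher from compound 3 to compound 4 (within the scatter) nor a number 6.1 percentage points higher from compound 1 to compound 4 (within the scatter) clears the scatter, so compound 4 separates from none of the other three, although compound 2 stands clear of both compound 1 and compound 3. No available evidence accounts for these numbers.

Still open, as far as these compounds go, is whether a single-ring aryl group at this position truly differs from bromo or naphthalen-1-yl once fluoro is present. From the compounds shown here alone, how an amine or a carboxylic acid on the phenyl would read also remains open.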